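A Methoxy Added to the Acid with the Lower Number

This account rests on a few compounds, and the source may have more. Where it says the series, first, only, none or still open, it means among the compounds named here.

Of the compounds shown here, two have been measured so far in a functional assay on MDA-MB-435 cells (Homo sapiens) for cytotoxicity, read by MTT assay, tested at 20 uM; a higher number here means more inhibition at the concentration tested (going by the name of the read-out), a lower number less inhibition. Compound 1, `CCOc1cc(/C=N/Nc2nc(Nc3ccccc3)nc(N3CCCCC3)n2)ccc1OCC(=O)O`, gives 70% in this assay. Compound 2, `CN(C1=NC(=O)/C(=C\c2ccc(OCC(=O)O)cc2)S1)c1ccc(O)cc1`, gives 9% in this assay, which is the lower of the two numbers; compound 1 stands higher by a margin that goes beyond the usual scatter of this assay. For the measured compounds named here, the two compounds share no common core, so their gap cannot be traced to any single structural change, and no step between measured compounds is available.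

The next compound, compound 3, `COc1cc(/C=C2/SC(N(C)c3ccc(O)cc3)=NC2=O)ccc1OCC(=O)O`, is built on the core of compound 2. The only difference is this: methoxy in place of hydrogen on an aromatic carbon. Going by the values given here, nothing in the numbers so far shows what a methoxy group in this place does on this core. Among the compounds with values here, compound 1 carries an alkoxy group in a related position on its own core, but its higher number rests on a wholly different scaffold and offers no guide for the step. The step from compound 2 to compound 3 in this assay is therefore expected to be small, most likely within the scatter, in either direction. For compound 3 the estimated value in this assay is 15%, expected to fall between 0% and 40%, giving an expected step of a number 6 percentage points higher from compound 2 to compound 3 (within the scatter).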

Compound 3, a percentage reported as inhibition, at one concentration (the size of the read-out at that concentration, not a potency): 26%
Compound 3: the middle estimate sits 11 percentage points below what was measured; the measured number falls inside the stated range.
By their numbers in this assay, from the lowest: compound 2; then compound 3; then compound 1.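

For the compounds shown here, on the core shared by compound 2 and compound 3, this is the first change that can be read directly: in this assay, methoxy in place of hydrogen on an aromatic carbon, ortho to a carboxymethoxy group, gives a number 17 percentage points higher from compound 2 to compound 3 (beyond the scatter). The step is modest, but it shows that this aromatic carbon can carry methoxy without the number falling, something the unrelated core of compound 1 could not show. Nothing available explains the rise, and no measurement beyond the numbers themselves bears on it.

A single step leaves open whether the rise is particular to methoxy, or whether a hydroxyl group, a fluorine atom or a longer chain such as ethoxy on the same carbon would give a similar, larger or smaller number. It also leaves open whether the step depends on the carboxylic acid of the carboxymethoxy group, present in both compounds, and whether an amide or an ester in its place would keep the higher number of compound 3.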